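The source may report more compounds than this note shows. Statements on the series, on what has been measured and on what is new or still open speak of the compounds shown alone.

Of the compounds shown here, three sharing one core have been tested in a functional assay on MCF7 cells (Homo sapiens) for inhibition, read by CCK-8 assay, with a stated time of 48 h; a higher number here means a weaker inhibitor, a lower number a stronger inhibitor. Compound 1 `COc1cc(-c2cc3nccc(-c4cc(OC)c(OC)c(OC)c4)n3n2)cc(OC)c1OC` gives only a limit, > 10000 nM. Compound 2 `COc1cc(-c2cc3nccc(-c4c[nH]c5ccccc45)n3n2)cc(OC)c1OC` also gives only a limit, > 10000 nM. Compound 3 `COc1cc(-c2ccnc3cc(-c4ccccc4)nn23)cc(OC)c1OC` is the only one of the three with a true number, at 254 nM, so it is the single firm reference point in this assay.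

Compound 4 `C=Cc1ccc(-c2cc3nccc(-c4cc(OC)c(OC)c(OC)c4)n3n2)cc1` has not yet been measured. It keeps the framework of compound 3 but turns the phenyl into 4-vinylphenyl, with vinyl in place of hydrogen on an aromatic carbon, para to a large group: vinyl in place of hydrogen on an aromatic carbon.

Among the measured compounds shown here, no measured pair isolates this kind of change, so the expectation rests on compound 3 at 254 nM. The expected step, a 1.6-fold higher number from compound 3 to compound 4 (0.20 log units; within the scatter), is small and stays within the usual scatter, with a slight lean toward weaker inhibition. A much larger loss cannot be ruled out because of the limit of > 10000 nM in this assay, at which 2 of the 3 values shown sit. The range is therefore kept wide, and more room is left on the weak side. For compound 4 the estimated half-maximal inhibitory concentration is 400 nM, with an expected range from 80 nM to 3000 nM.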

Compound 4, half-maximal inhibitory concentration: 193 nM
Compound 4: the middle estimate sits 2.1-fold (0.32 log units) above what was measured, within the range that was stated.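

Vinyl in place of hydrogen on an aromatic carbon, para to a large group, gives in this assay a 1.3-fold lower number from compound 3 to compound 4 (0.12 log units; within the scatter). Among the compounds shown here, this is the first reading at this position, and it shows that the position can carry vinyl, with its 2 carbon atoms and its double bond, while the read-out stays a true number: compound 4 gives 193 nM, not a limit, and the large loss held open for it did not appear. Within the usual scatter, compound 3 and compound 4 cannot be told apart, so this single pair sets no order between hydrogen and vinyl and offers no trend for the position.

Going by these compounds, what an amine, a carboxylic acid or a longer chain would do on this same aromatic carbon stays open, as does the question of whether the double bond of the vinyl matters at all, which ethyl in its place would address. The firm ground for any such reading also remains thin in this assay: the limit of > 10000 nM in this assay, at which 2 of the 4 values shown sit.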